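From benzyl to 3-fluorobenzyl on compound 1

The compounds below may be only part of what the source reports. "The series", "measured", "known", "first", "only" and "open" are said of these compounds alone.

Measured so far in a functional assay on HL-60 cells (Homo sapiens) for inhibition, read by CCK-8 assay, with a stated time of 48 h, tested at 20 uM; on this read-out higher numbers stand for more inhibition of growth at the one concentration tested and lower numbers for less inhibition of growth
compound 1 `N#C/C(=C\c1ccccc1OS(=O)(=O)c1ccccc1[N+](=O)[O-])C(=O)Nc1nnc(Cc2ccccc2)s1` at 12%
compound 2 `N#C/C(=C\c1ccccc1OS(=O)(=O)c1ccc(F)cc1)C(=O)Nc1nnc(Cc2ccccc2)s1` at 22%

Compound 1 has a single neighbour on this scale and cannot be separated from it. For the measured compounds named here, the only measured step is a number 10 percentage points higher from compound 1 to compound 2 (within the scatter) and it concerns the group on the sulfonyl sulfur, 4-fluorophenyl in place of 2-nitrophenyl.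

Compound 3 `N#C/C(=C\c1ccccc1OS(=O)(=O)c1ccccc1[N+](=O)[O-])C(=O)Nc1nnc(Cc2cccc(F)c2)s1` differs from compound 1 by fluoro in place of hydrogen on an aromatic carbon and the change reads benzyl to 3-fluorobenzyl. Going by the values given here, no measured step covers this place, so the step on the sulfonyl side offers only a loose guide to size. In this assay no change beyond the scatter is expected, and no direction can be assigned.

The expected step is a number 3 percentage points higher from compound 1 to compound 3 (within the scatter) and it is only an estimate. Compound 3 is estimated at 15% and expected to fall from 4% to 30% on measurement.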

Compound 3, percent growth inhibition at one concentration: 23%
Compound 3: the middle estimate sits 8 percentage points below what was measured; measured number inside the range.
By their numbers in this assay, from the lowest: compounds 1, 2 and 3 (each within the scatter of the next, the first and the last beyond it).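

In this assay the change from benzyl to 3-fluorobenzyl gives a number 11 percentage points higher from compound 1 to compound 3 (beyond the scatter) and is the first step shown at this end of the molecule, as the earlier pair differed only in the group on the sulfonyl sulfur. Activity at the one concentration tested therefore responds to a single fluoro in place of hydrogen on this aromatic carbon, although the step is modest and rests on one pair. No available evidence explains this step.

The compounds shown leave open whether the same step would appear with 4-fluorophenyl on the sulfonyl sulfur. They also leave open whether fluoro is special at this place or whether chloro, methoxy or an amine there would give a similar, larger or smaller number.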